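A second 4-nitrobenzyl group on the shared core

The compounds below may be only part of what the source reports. "The series", "measured", "known", "first", "only" and "open" are said of these compounds alone.

Two closely related compounds have been measured so far. In a functional assay on MCF7 cells (Homo sapiens) for antiproliferative activity (on this read-out lower numbers stand for stronger inhibition and higher numbers for weaker inhibition), compound 1 `COC1=C(OCc2ccc([N+](=O)[O-])cc2)/C(=C\Cn2cnc3c(Cl)ncnc32)OC1=O` gives 15400 nM and compound 2 `COC1=C(OCc2ccc([N+](=O)[O-])cc2)C(=O)O/C1=C/Cn1cnc2c(Cl)ncnc21` gives 14200 nM on the same scale. These two numbers lie within the usual scatter of each other, so compound 2 stands level with compound 1 and neither can be ranked above the other.

The next compound, compound 3 `O=C1O/C(=C/Cn2cnc3c(Cl)ncnc32)C(OCc2ccc([N+](=O)[O-])cc2)=C1OCc1ccc([N+](=O)[O-])cc1`, differs from compound 2 in one place 4-nitrophenyl in place of hydrogen on a saturated chain carbon bound to an oxygen on an unsaturated carbon where 4-nitrophenyl takes the place of hydrogen on a saturated chain carbon bound to an oxygen on an unsaturated carbon. Put another way, the methoxy group becomes a (4-nitrobenzyl)oxy group. Going by the values given here, no measured pair shows what this swap does, so any forecast here is uncertain. In this assay only a small move toward lower numbers is expected, with the estimated change being a 1.8-fold lower number from compound 2 to compound 3 (0.25 log units; within the scatter) and thus no larger than ordinary scatter. The estimate for compound 3 is 8000 nM with an expected range from 2500 nM to 22000 nM in a repeated measurement.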

Compound 3, half-maximal inhibitory concentration: > 120000 nM
Compound 3: a limit, no number; the forecaster's own chance of this, stated with the estimate: 10%; at least 15-fold (1.17 log units) between middle value and limit.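

In this assay compound 3 gives > 120000 nM, which is a limit of the assay and not a number. Changing the methoxy group to a (4-nitrobenzyl)oxy group produces the first difference in this series that lies beyond the scatter, with an at least 8.4-fold higher number from compound 2 to compound 3 (0.92 log units; beyond the scatter) and, by the same change, an at least 7.7-fold higher number from compound 1 to compound 3 (0.89 log units; beyond the scatter). As far as these compounds go, the earlier pair gave no information about this position, but these steps show that activity here is sensitive to the group on the oxygen and that this particular swap brings a clear loss of antiproliferative activity, whose full size remains unknown.

The compounds shown leave open whether the loss belongs to the 4-nitrophenyl group itself or would follow from any replacement of the methyl, a question that an ethyl group, a plain benzyl group or a benzyl group carrying an amine or a carboxylic acid in place of the nitro group could help to settle. They also leave open whether any group at this place can give lower numbers than the methoxy group does.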